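Notes on removing the isopropylcarbamoyl group from compound 2

The source may hold more compounds than are shown below. What is called first, only, known or untested is meant among the compounds shown, and "the series" means these compounds.

Measured compounds:
- compound 1 `CC(C)(C)NC(=O)NCCS(=O)(=O)NC(=O)c1ccc(Nc2nc(NC3(c4ccc(Cl)cc4)CC3)nc(OCC(F)(F)F)n2)cc1`: in an ADME assay on microsomes from liver (Homo sapiens) for metabolic stability, with a stated time of 10 min (on this read-out lower numbers stand for a less stable compound and higher numbers for a more stable compound), compound 1 gives 96%.
- compound 2 `CC(C)NC(=O)NCCS(=O)(=O)NC(=O)c1ccc(Nc2nc(NC3(c4ccc(Cl)cc4)CC3)nc(OCC(F)(F)F)n2)cc1`: in this assay compound 2 gives 100%.

Compound 2 stands highest of the two numbers recorded so far; its nearest neighbour is compound 1, and the step of a number 4 percentage points higher from compound 1 to compound 2 (within the scatter) lies within the scatter, so no order between the two is claimed.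

Compound 3 `NCCS(=O)(=O)NC(=O)c1ccc(Nc2nc(NC3(c4ccc(Cl)cc4)CC3)nc(OCC(F)(F)F)n2)cc1` has not yet been measured in this assay. Compared with compound 2, the difference is hydrogen in place of isopropylcarbamoyl on an amine nitrogen. Going by the values given here, the only measured step, a number 4 percentage points higher from compound 1 to compound 2 (within the scatter), concerns a change of another kind, so it bears on the present step only loosely. With both measured compounds near the top of the read-out, a drop for compound 3 is possible, but no step beyond the scatter is expected. Compound 3 is estimated at 90%, within 70% to 100%, which means an expected step of a number 10 percentage points lower from compound 2 to compound 3 (within the scatter).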

Compound 3, percent of the compound remaining: 100%
Beside the measured number, compound 3's estimate is 10 percentage points below it, and the stated range covers the measured number.
By their numbers in this assay, from the lowest: compounds 1, 2 and 3 (each within the scatter of the next).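

In this assay, removing the isopropylcarbamoyl group from the amine nitrogen gives no change at the digits printed from compound 2 to compound 3 (within the scatter), so the free 2-aminoethyl chain shows no step beyond the scatter. Replacing (tert-butyl)carbamoyl with hydrogen at the same nitrogen gives a number 4 percentage points higher from compound 1 to compound 3 (within the scatter), so neither urea substituent is needed to keep the number near the top of this read-out, and the three compounds cannot be ordered. No supporting measurement is available to explain this result.

From the compounds shown here alone, it remains open whether an acetyl or methyl group on the amine nitrogen, or a longer chain in place of 2-aminoethyl, would hold this level in this assay. A carboxylic acid in place of the amine is equally untested among the compounds shown.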